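Swapping the Ring on the Nitrogen of Compound 3

The source may hold more compounds than are shown below. What is called first, only, known or untested is meant among the compounds shown, and "the series" means these compounds.

Of the compounds shown here, three sharing one core have been tested in an ADME assay on RAW264.7 cells (Mus musculus) for cytotoxicity, read by MTT assay, with a stated time of 48 h, tested at 50 uM; on this read-out higher numbers stand for more inhibition at the one concentration tested (going by the name of the read-out) and lower numbers for less inhibition. Compound 1 `N=C1S/C(=C\c2ccc(OCc3ccccc3)cc2)C(=O)N1c1ccccc1[N+](=O)[O-]` gives 24.4%. Compound 2 `N=C1S/C(=C\c2ccc(OCc3ccccc3)cc2)C(=O)N1c1ccc(Cl)cc1Cl` gives 13.8%. Compound 3 `N=C1S/C(=C\c2ccc(OCc3ccccc3)cc2)C(=O)N1c1ncccn1` gives 26.6%, the highest of the three numbers; the nearest is compound 1, within the scatter, and the furthest is compound 2, beyond the scatter.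

Compound 4 `Cc1ccc(N2C(=N)S/C(=C\c3ccc(OCc4ccccc4)cc3)C2=O)c(C)c1` has not yet been measured in this assay. It differs from compound 3 in one place (2,4-dimethylphenyl in place of pyrimidin-2-yl on an amide-type nitrogen in a ring).

Going by the values given here, two measured steps bear on this change, both swapping the ring on the same amide-type nitrogen. The step of a number 2.2 percentage points higher from compound 1 to compound 3 (within the scatter) lay within the scatter, so exchanging a nitrophenyl for the pyrimidin-2-yl ring changed little. The step of a number 12.8 percentage points higher from compound 2 to compound 3 (beyond the scatter) was modest and beyond the scatter, so a dichlorophenyl ring in that place went with a lower number than the pyrimidin-2-yl ring. Compound 4 carries a carbon-only ring in that place, like compound 2 and compound 1, so a small drop or no change beyond the scatter is expected in this assay.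

The expected step is a number 7.6 percentage points lower from compound 3 to compound 4 (within the scatter). Compound 4 is therefore estimated at 19%, within a range from 6% to 32%.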

Compound 4, a percentage reported as inhibition, at one concentration (the size of the read-out at that concentration, not a potency): 36.8%
Estimate against measurement, compound 4: 17.8 percentage points below, outside the stated range (above it).
By their numbers in this assay, from the lowest: compound 2; then compounds 1 and 3 (each within the scatter of the next); then compound 4.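

In this assay, a carbon-only ring on this amide-type nitrogen does not by itself go with a lower number, since replacing pyrimidin-2-yl with 2,4-dimethylphenyl gave a number 10.2 percentage points higher from compound 3 to compound 4 (beyond the scatter). The groups carried by the carbon-only ring also matter: 2,4-dimethylphenyl in place of 2,4-dichlorophenyl gave a number 23 percentage points higher from compound 2 to compound 4 (beyond the scatter), although the two rings differ only in having methyl groups rather than chlorine atoms. Compared with the 2-nitrophenyl ring, another carbon-only ring, the change gave a number 12.4 percentage points higher from compound 1 to compound 4 (beyond the scatter), so the three carbon-only rings do not share one level, and compound 4 now has the highest number of the four.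

The compounds shown leave open how an unsubstituted phenyl ring, a cyclohexyl ring or a phenyl ring bearing an amine would read at this nitrogen, so it remains unclear which feature of 2,4-dimethylphenyl goes with the higher number. No measurement is available here that would explain why these rings give different numbers.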